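The compounds below may be only part of what the source reports. "The series", "measured", "known", "first", "only" and "open" are said of these compounds alone.

Three compounds share one core and differ only in the group carried on the sulfonyl sulfur. In an assay on isolated protein for binding affinity to phosphatidylinositol 4,5-bisphosphate 3-kinase catalytic subunit beta isoform (Homo sapiens) (a lower number here means tighter binding, a higher number weaker binding), compound 1 `CS(=O)(=O)Nc1cncc(-c2cnc(N)nc2)c1` gives 5200 nM. Compound 2 `Nc1ncc(-c2cncc(NS(=O)(=O)c3ccc(F)cc3F)c2)cn1` gives 220 nM in this assay, and compound 3 `Nc1ncc(-c2cncc(NS(=O)(=O)c3ccc([N+](=O)[O-])cc3)c2)cn1` gives 550 nM. Compound 3 thus stands second highest of the three numbers: compound 2 has a lower number and compound 1 a higher one, each gap beyond the scatter.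

Compound 4 `COc1ccc(S(=O)(=O)Nc2cncc(-c3cnc(N)nc3)c2)cc1` differs from compound 3 in one place: methoxy in place of nitro on an aromatic carbon. Among the measured compounds shown here, only one measured step is at hand, a 24-fold lower number from compound 1 to compound 2 (1.37 log units; beyond the scatter), and it concerns the whole group on the sulfur rather than one substituent on an aromatic ring. Compound 2 at 220 nM and compound 3 at 550 nM show that two rings bearing different substituents give numbers not far apart, so swapping one substituent within such a ring is expected to move the number only modestly. The expected step is therefore a 1.4-fold lower number from compound 3 to compound 4 (0.14 log units; within the scatter), in no firm direction. Compound 4 is estimated at 400 nM, with a range from 150 nM to 1200 nM.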

Compound 4, dissociation constant: 500 nM
Beside the measured number, compound 4's estimate is 1.3-fold (0.10 log units) below it, within the range that was stated.
By their numbers in this assay, from the lowest: compound 2; then compounds 4 and 3 (each within the scatter of the next); then compound 1.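

In this assay, nitro and methoxy cannot be told apart at this place on the aromatic ring, para to a large group (a 1.1-fold lower number from compound 3 to compound 4 (0.04 log units; within the scatter)), so the read-out does not separate these two substituents. The large gain over the methyl group of compound 1, first seen with the 2,4-difluorophenyl group, also appears with the 4-methoxyphenyl group (a 10-fold lower number from compound 1 to compound 4 (1.02 log units; beyond the scatter)). The 2,4-difluorophenyl group still keeps a modest edge over the 4-methoxyphenyl group (a 2.3-fold higher number from compound 2 to compound 4 (0.36 log units; beyond the scatter)), so the choice of ring on the sulfur does matter, if only by a small margin.

From the compounds shown here alone, whether an amine or a carboxylic acid at this ring position would also leave the number in the same range remains open. Nothing available here explains why these numbers fall as they do.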